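This account rests on a few compounds, and the source may have more. Where it says the series, first, only, none or still open, it means among the compounds named here.

Measured compounds:
compound 1, `Cc1ccc(-c2ncccn2)c(C(=O)N2CC3(CC3)C[C@H]2CNc2ccc(C(F)(F)F)cn2)n1`, 7.5
compound 2, `Cc1nc(C(=O)N2CC3(CC3)C[C@H]2CNc2cc(C(F)(F)F)ccn2)c(-c2ccccc2)s1`, 8.5
compound 3, `Cc1nc(C(=O)N2CC3(CC3)C[C@H]2CNc2ccc(C(F)(F)F)cn2)c(-c2ccccc2)s1`, 7.7

In a functional assay on HEK293 cells for antagonist activity at Orexin receptor type 2 (Homo sapiens), read by FLIPR and calcium flux (a lower number here means a less potent compound, a higher number a more potent compound, by a factor of ten per unit of this negative logarithm), compound 1 gives 7.5, the lowest of the three values; its nearest neighbour is compound 3, whose value lies within the scatter of it, and its furthest is compound 2. Compound 3 and compound 2 share a core and differ only in the group on the amine nitrogen: 4-(trifluoromethyl)pyridin-2-yl in place of 5-(trifluoromethyl)pyridin-2-yl on an amine nitrogen. That change gave a number 0.80 log units higher from compound 3 to compound 2 (beyond the scatter).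

Compound 4, `Cc1ccc(-c2ncccn2)c(C(=O)N2CC3(CC3)C[C@H]2CNc2cc(C(F)(F)F)ccn2)n1`, is not yet measured. It relates to compound 1 exactly as compound 2 relates to compound 3: 4-(trifluoromethyl)pyridin-2-yl in place of 5-(trifluoromethyl)pyridin-2-yl on an amine nitrogen, at a place described in the same words in both pairs, so it is the same change. The cores of compound 1 and compound 3 differ, but the difference between the two cores is not broken down here.

Resting on the single observed step, compound 4 is expected to gain about as much as compound 2 did over compound 3, namely a number 0.80 log units higher from compound 1 to compound 4 (beyond the scatter). With the core of compound 1 untested for this change, compound 4 is estimated at 8.3, likely between 7.8 and 8.8.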

Compound 4, negative logarithm of the antagonist equilibrium constant: 8.1
Beside the measured number, compound 4's estimate is 0.20 log units above it; the range from low to high includes it.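

In this assay, 4-(trifluoromethyl)pyridin-2-yl in place of 5-(trifluoromethyl)pyridin-2-yl on the amine nitrogen gave a number 0.60 log units higher from compound 1 to compound 4 (beyond the scatter). This step agrees with the earlier one on the other core, so the change carried over between these two cores with much the same size: the same change on two cores in this assay, a number 0.80 log units higher (beyond the scatter) from compound 3 to compound 2 and a number 0.60 log units higher (beyond the scatter) from compound 1 to compound 4, 0.20 log units apart, within the scatter of two such steps That agreement rests on just two pairs of compounds, so it shows that the change transferred once but does not establish a rule for the whole series, and it does not explain why the number rises.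

The compounds shown leave open whether the same gain would appear on a third core, or whether it depends on the trifluoromethyl group itself. A nitrile or a chlorine in place of trifluoromethyl on the pyridine, or a pyridin-2-yl with no such group at all, would speak to that second question.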